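Swapping the halophenyl on the ketone of compound 1

The compounds below may be only part of what the source reports. "The series", "measured", "known", "first", "only" and "open" are said of these compounds alone.

Compound 1 `COc1cc(-c2nnc3n2NC(c2ccco2)C(C(=O)c2ccc(Cl)cc2)S3)cc(OC)c1OC`: 67800 nM
Compound 2 `COc1cc(C(=O)C2Sc3nnc(-c4cc(OC)c(OC)c(OC)c4)n3NC2c2cccs2)cc(OC)c1OC`: > 100000 nM
Compound 3 `COc1ccc(C(=O)C2Sc3nnc(-c4cc(OC)c(OC)c(OC)c4)n3NC2c2cccs2)cc1`: 95900 nM

In a functional assay on PC-3 cells (Homo sapiens) for cytotoxicity, read by MTT assay, with a stated time of 48 h (on this read-out higher numbers stand for weaker inhibition and lower numbers for stronger inhibition), compound 1 gives 67800 nM. Compound 3 gives 95900 nM in this assay, and the two values sit within the scatter of each other. For compound 2 this assay reports only a limit, > 100000 nM, and no number. Within the data shown here, the one step measured between these compounds, an at least 1.0-fold lower number from compound 2 to compound 3 (0.01 log units; that floor lies within the scatter), concerns the aryl group on the carbonyl carbon and stays within the scatter; it does not touch the place changed here, so no measured step bears directly on the new compound.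

Compound 4 `COc1cc(-c2nnc3n2NC(c2ccco2)C(C(=O)c2cccc(Br)c2)S3)cc(OC)c1OC` differs from compound 1 by 3-bromophenyl in place of 4-chlorophenyl on a carbonyl carbon. Among the measured compounds shown here, since the only recorded change at a carbonyl carbon left the read-out unchanged, no step beyond the scatter is expected from compound 1 to compound 4, and the value may again come out as a limit, as seen for compound 2 (the limit of > 100000 nM in this assay, at which 1 of the 3 values shown sits). The estimated step is a 1.0-fold higher number from compound 1 to compound 4 (0.01 log units; within the scatter). Compound 4 is therefore expected to give about 70000 nM in this assay, between 25000 nM and 200000 nM.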

Compound 4, half-maximal inhibitory concentration: 63900 nM
For compound 4 the middle estimate is 1.1-fold (0.04 log units) above the measured one; low and high end bracket the measured number.
By their numbers in this assay, from the lowest: compounds 4, 1 and 3 (each within the scatter of the next). At a limit, above all of these: compound 2.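

In this assay, putting 3-bromophenyl in place of 4-chlorophenyl on the carbonyl carbon gives a 1.1-fold lower number from compound 1 to compound 4 (0.03 log units; within the scatter). The earlier step at a carbonyl carbon had a limit at one end and so gave only a floor, whereas this step joins two measured numbers and shows that this exchange, which alters both the halogen and its place on the phenyl ring, leaves the read-out within the scatter. Compound 4 also returns a number rather than a limit: the limit of > 100000 nM in this assay, at which 1 of the 4 values shown sits.

The two aryl groups differ in both halogen and substitution, so the compounds shown cannot separate these two changes. On these data alone, it also remains open whether an amine or a carboxylic acid on that phenyl ring would move the number in this assay beyond the scatter.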